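Chloro in place of methoxy on the aromatic ring

The source may report more compounds than this note shows. Statements on the series, on what has been measured and on what is new or still open speak of the compounds shown alone.

Of the compounds shown here, three on the shared core have been read in a functional assay on HeLa cells (Homo sapiens) for inhibition, read by sulforhodamine B assay; on this read-out higher numbers stand for weaker inhibition and lower numbers for stronger inhibition. Compound 1 `O=C1C(NC2CCCC2)=CC(=O)c2c1nc1n2[C@H]2OC[C@@H](O)[C@H]2OC1` gives > 16000 nM, a limit of the assay. Among the measured compounds shown here, compound 2 `Cc1ccc(NC2=CC(=O)c3c(nc4n3[C@H]3OC[C@@H](O)[C@H]3OC4)C2=O)cc1` gives 6590 nM, the only actual number so far. Compound 3 `COc1cccc(NC2=CC(=O)c3c(nc4n3[C@H]3OC[C@@H](O)[C@H]3OC4)C2=O)c1` gives > 8000 nM, also a limit, so its standing is known from one side only.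

Compound 4 `O=C1C(Nc2cccc(Cl)c2)=CC(=O)c2c1nc1n2[C@H]2OC[C@@H](O)[C@H]2OC1` differs from compound 3 by chloro in place of methoxy on an aromatic carbon, with chloro in place of methoxy on an aromatic carbon, meta to a large group. For the measured compounds named here, no measured step covers this exact change. The nearest evidence is an at least 1.2-fold higher number from compound 2 to compound 3 (0.08 log units; that floor lies within the scatter), whose floor lies within the scatter, while a step that the two limits leave unreadable from compound 1 to compound 3 cannot be read. Only an at least 2.4-fold lower number from compound 1 to compound 2 (0.38 log units; beyond the scatter) lies beyond the scatter, and it concerns a different change. In this assay, a small step towards a lower number is therefore expected, possibly none beyond the scatter. The expected step is an at least 1.1-fold lower number from compound 3 to compound 4 (0.05 log units; that floor lies within the scatter). For compound 4 the estimated value is 7000 nM, with an expected range of 3000 nM to 16000 nM.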

Compound 4, half-maximal inhibitory concentration: 7970 nM
The estimate for compound 4 lay 1.1-fold (0.06 log units) below the measured number, within the range that was stated.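

In this assay, 3-chlorophenyl in place of 4-methylphenyl on the amine nitrogen gives a 1.2-fold higher number from compound 2 to compound 4 (0.08 log units; within the scatter), so these two aromatic groups cannot be told apart here. Against the cyclopentyl group the result is an at least 2.0-fold lower number from compound 1 to compound 4 (0.30 log units; that floor lies within the scatter), so compound 4 alone does not establish a gain over compound 1, although compound 2 does. Compound 3 carries a limit. Chloro in place of methoxy gives a number no higher from compound 3 to compound 4 (the limit leaves the size open), and the steps that depend on that limit cannot be read: the limit of > 8000 nM in this assay, at which 1 of the 4 values shown sits.

As far as these compounds go, whether any group on this aromatic carbon moves the value beyond the scatter remains open; an amine or a carboxylic acid there would test that against chloro. A 4-chlorophenyl group would separate the effect of the group from that of its place on the ring.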